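The source may hold more compounds than are shown below. What is called first, only, known or untested is meant among the compounds shown, and "the series" means these compounds.

Compound 1 `Nc1nc(N)c2c(-c3ccsc3)cn([C@@H]3O[C@H](CO)[C@@H](O)[C@H]3O)c2n1` gives > 100000 nM in an ADME assay on MRC5 cells (Homo sapiens), read by MTT assay, with a stated time of 72 h (on this read-out lower numbers stand for stronger inhibition and higher numbers for weaker inhibition), which is a limit of the assay.
Compound 2 `Nc1nc(N)c2c(-c3ccccc3)cn([C@@H]3O[C@H](CO)[C@@H](O)[C@H]3O)c2n1` gives > 100000 nM in this assay, which is a limit of the assay.
Compound 3 `Nc1nc2c(c(-c3ccccc3)cn2[C@@H]2O[C@H](CO)[C@@H](O)[C@H]2O)c(=O)[nH]1` gives > 100000 nM in this assay, which is a limit of the assay.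

Of the compounds shown here, three have been measured so far, and all three sit at the same limit (the limit of > 100000 nM in this assay, at which 3 of the 3 values shown sit). Compound 2 and compound 1 share a core and differ in one place, the change being (thiophen-3-yl in place of phenyl on an aromatic carbon). The step between them is a step that the two limits leave unreadable from compound 2 to compound 1, so the size of this step cannot be read from the two limits. Compound 3 carries a different core from compound 2; the difference between the two cores is not broken down here.

Compound 4 `Nc1nc2c(c(-c3ccsc3)cn2[C@@H]2O[C@H](CO)[C@@H](O)[C@H]2O)c(=O)[nH]1` has not yet been measured in this assay. It differs from compound 3 by thiophen-3-yl in place of phenyl on an aromatic carbon, the same change that leads from compound 2 to compound 1, made at a place described in the same words. Since this change gave an unreadable step between two limits, and compound 3 itself sits at a limit, the same outcome is expected for compound 4: the step that the limit leaves unreadable from compound 3 to compound 4 is estimated to be flat at the limit. This expectation rests on compound 3 giving > 100000 nM in this assay. It rests further on the step that the two limits leave unreadable from compound 2 to compound 1, which the two limits leave unreadable. Compound 4 is therefore expected to give about 150000 nM, estimated between 100000 nM and 300000 nM, most likely reported only as a limit.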

Compound 4, half-maximal inhibitory concentration: > 100000 nM
Compound 4: no number, only a limit; the forecaster's own chance of this, stated with the estimate: 90%; the middle value is on the limit's open side.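

Within the data shown here, compound 4 gives > 100000 nM in this assay and this is a limit of the assay, so neither the step from compound 3 to compound 4 nor the one from compound 2 to compound 1 can be read. The compounds shown leave open how phenyl and thiophen-3-yl compare on either core, and how far any of the four lies from that reading, which all of them share: the limit of > 100000 nM in this assay, at which 4 of the 4 values shown sit.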